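Halogenated phenyl on the ring nitrogen of compound 3

The source may report more compounds than this note shows. Statements on the series, on what has been measured and on what is new or still open speak of the compounds shown alone.

The series shares one core, varied at the amide alkyl and at the aryl on the ring nitrogen. Compound 1 `CNC(=O)c1cc(Oc2ccc(NC(=O)c3cc4cccnc4n(-c4ccccc4)c3=O)cc2)ccn1` carries a methylamide and a plain phenyl; in a functional assay on NCI-H460 cells (Homo sapiens) for antiproliferative activity, read by MTT assay, with a stated time of 72 h (a higher number here means a weaker inhibitor, a lower number a stronger inhibitor), compound 1 gives 320 nM. Compound 3 `CCNC(=O)c1cc(Oc2ccc(NC(=O)c3cc4cccnc4n(-c4ccccc4)c3=O)cc2)ccn1` carries an ethylamide instead, and in this assay compound 3 gives 1120 nM, the highest of the two numbers available; the step of a 3.5-fold higher number from compound 1 to compound 3 (0.54 log units; beyond the scatter) is modest but beyond the scatter. Compound 2 `CNC(=O)c1cc(Oc2ccc(NC(=O)c3cc4cccnc4n(-c4ccc(Cl)cc4)c3=O)cc2)ccn1` has a 4-chlorophenyl on the ring nitrogen, yet in this assay compound 2 gives "not determined" (no result reported), so nothing about aryl substitution can be read from it.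

Compound 4 `CCNC(=O)c1cc(Oc2ccc(NC(=O)c3cc4cccnc4n(-c4ccc(Br)cc4F)c3=O)cc2)ccn1` differs from compound 3 in one place: 4-bromo-2-fluorophenyl in place of phenyl on an aromatic nitrogen. Going by the values given here, no measured step touches this position; the only step on record, from compound 1 to compound 3, concerns the amide alkyl and does not bear on the aryl. With no guidance, compound 4 is expected to stay close to compound 3 in this assay, with a 1.1-fold lower number from compound 3 to compound 4 (0.05 log units; within the scatter) not expected to exceed the scatter. The estimate for compound 4 in this assay is 1000 nM, within a range from 300 nM to 3500 nM that allows for the unknown effect of the halogens.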

Compound 4, half-maximal inhibitory concentration: 1790 nM
Beside the measured number, compound 4's estimate is 1.8-fold (0.25 log units) below it; low and high end bracket the measured number.
By their numbers in this assay, from the lowest: compound 1; then compounds 3 and 4 (each within the scatter of the next).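

In this assay, going by these compounds alone, the first readable change at the aryl on the ring nitrogen is a 1.6-fold higher number from compound 3 to compound 4 (0.20 log units; within the scatter) and so leaves compound 3 and compound 4 indistinguishable. The earlier compounds shown here could say nothing about this position, whereas this pair shows that, on the ethylamide background, the plain phenyl can give way to 4-bromo-2-fluorophenyl, a group of 8 heavy atoms rather than 6 that carries two halogens, with no change that rises above the scatter. Nothing available here explains this outcome, and the result alone cannot say what either halogen contributes.

Within the data shown here, the single pair cannot separate the bromine from the fluorine, so it remains open whether either halogen alone on the phenyl would give the same picture, and whether the 4-bromo-2-fluorophenyl would behave the same way on the methylamide of compound 1. On these data alone, it also remains open how this position would respond to an aryl bearing an amine or a carboxylic acid, or to a longer alkyl chain in place of the aryl.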